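The source may report more compounds than this note shows. Statements on the series, on what has been measured and on what is new or still open speak of the compounds shown alone.

Measured compounds:
compound 1 `C=CC(=O)Nc1ccc(-c2nc(Cl)cc(Nc3ccc(C(=O)N(CC)CC)cc3)n2)cc1` — 12500 nM
compound 2 `C=CC(=O)Nc1ccc(-c2nc(Cl)cc(Nc3ccc(C(=O)Nc4ccc(OC)cc4)cc3)n2)cc1` — "not determined" (no result reported)
compound 3 `C=CC(=O)Nc1ccc(-c2nc(Cl)cc(Nc3ccc(C(=O)Nc4cccc(C)c4)cc3)n2)cc1` — 6980 nM

In a functional assay on Raji cells (Homo sapiens) for antiproliferative activity, read by MTT assay, with a stated time of 48 h (a lower number here means a stronger inhibitor, a higher number a weaker inhibitor), compound 1 gives 12500 nM. Compound 2 gives "not determined" (no result reported), so only compounds 1 and 3 carry numbers. Among the compounds with values here, the one step that can be read, a 1.8-fold lower number from compound 1 to compound 3 (0.25 log units; within the scatter), lies within the scatter, so compound 1 and compound 3 are not separated by this assay.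

Compound 4 `C=CC(=O)Nc1ccc(-c2nc(Cl)cc(Nc3ccc(C(=O)N(C)C)cc3)n2)cc1` is not yet measured. It differs from compound 1 in one place: dimethylamino in place of diethylamino on a carbonyl carbon. Within the data shown here, no measured step covers this change. Among the measured compounds shown here, the only step in hand replaces the diethylamino with a (3-methylphenyl)amino on the same carbonyl carbon, and that step, a 1.8-fold lower number from compound 1 to compound 3 (0.25 log units; within the scatter), stayed within the scatter; a shortening of the two ethyl chains to methyl has nothing of its own to go on. The working expectation is therefore no step beyond the scatter in this assay.

Compound 4 is expected near 12500 nM, with a range from 5000 nM to 32000 nM. The step this estimate means, no change at the digits printed from compound 1 to compound 4 (within the scatter), is expected to stay within the scatter.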

Compound 4, half-maximal inhibitory concentration: 42900 nM
Compound 4: the middle estimate sits 3.4-fold (0.54 log units) below what was measured; measured number above the stated range.
By their numbers in this assay, from the lowest: compounds 3 and 1 (each within the scatter of the next); then compound 4.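

In this assay the change from diethylamino to dimethylamino on this carbonyl carbon gives a 3.4-fold higher number from compound 1 to compound 4 (0.54 log units; beyond the scatter) and so, unlike the earlier step at the same place, goes beyond the scatter. The place is therefore not indifferent to its substituent: a 6.1-fold higher number from compound 3 to compound 4 (0.79 log units; beyond the scatter) also lies beyond the scatter, which leaves compound 4 the weakest of the three numbered compounds, while compounds 1 and 3 stay unseparated. Nothing available explains the size of this step.

Going by these compounds, with only the diethylamino and dimethylamino pair in hand, it stays open whether the trend runs on to a longer chain such as dipropylamino or to a cyclic amine such as piperidine on the same carbonyl carbon. On these data alone, it also stays open whether a benzylamino group would track with the (3-methylphenyl)amino of compound 3.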